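A few compounds are considered here, and "the series" means these few. Any claim that something is new, unique, unknown or untested is made for them only; others in the source may bear on it.

Measured so far in a functional assay on MV4-11 cells (Homo sapiens) for antiproliferative activity, read by CCK-8 assay, with a stated time of 72 h; on this read-out lower numbers stand for stronger inhibition and higher numbers for weaker inhibition:
Compound 1 `Cn1cc(-c2ccccc2Oc2ccccc2)c2cc(C(=O)NCc3ccc(C(=O)Nc4ccccc4N)cc3)[nH]c2c1=O`: 80 nM
Compound 2 `COc1ccc(C(C)(C)O)cc1-c1cn(C)c(=O)c2[nH]c(C(=O)NCc3ccc(C(=O)Nc4ccccc4N)cc3)cc12`: 420 nM

Compound 2, at 420 nM, holds the higher of the two numbers, and its gap to compound 1 lies beyond the usual scatter of repeated measurements. Compound 3 `Cn1cc(-c2cc(C(C)(C)O)ccc2Oc2ccccc2)c2cc(C(=O)NCc3ccc(C(=O)Nc4ccccc4N)cc3)[nH]c2c1=O` has not yet been measured. It matches compound 2 except at one place: phenyl in place of methyl on an oxygen on an aromatic ring. This puts phenyl in place of methyl on an oxygen on an aromatic ring, turning methoxy into phenoxy. Compound 1 also carries phenoxy and gives 80 nM, although it differs from compound 3 elsewhere. Within the data shown here, no measured pair shows this change alone, so the expectation is tentative. In this assay a moderate fall beyond the scatter is expected, a 2.6-fold lower number from compound 2 to compound 3 (0.42 log units; beyond the scatter). For compound 3 the estimated value is 160 nM, with an expected range of 50 nM to 500 nM.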

Compound 3, half-maximal inhibitory concentration: 100 nM
Estimate against measurement, compound 3: 1.6-fold (0.20 log units) above; low and high end bracket the measured number.
By their numbers in this assay, from the lowest: compounds 1 and 3 (each within the scatter of the next); then compound 2.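

Phenyl in place of methyl on an oxygen on an aromatic ring can now be read on its own in this assay and gives a 4.2-fold lower number from compound 2 to compound 3 (0.62 log units; beyond the scatter) so on this scaffold phenoxy goes with stronger inhibition than methoxy. With phenoxy in place, 1-hydroxy-1-methylethyl in place of hydrogen on an aromatic carbon gives a 1.3-fold higher number from compound 1 to compound 3 (0.10 log units; within the scatter) and so compound 1 and compound 3 cannot be told apart in this read-out. No outside measurement is available to explain either step.

As far as these compounds go, it remains open whether a ring is needed on that oxygen, or whether a longer chain such as ethoxy or a saturated ring such as cyclohexyl would serve equally well. From the compounds shown here alone, it is also open how an amine or a carboxylic acid would behave in place of 1-hydroxy-1-methylethyl.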